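The source may report more compounds than this note shows. Statements on the series, on what has been measured and on what is new or still open speak of the compounds shown alone.

Measured so far:
compound 1 `Cc1nc(-c2ccc(C(F)(F)F)cc2)sc1CNc1ccc(CCCC(=O)O)cc1` — < 10000 nM
compound 2 `O=C(O)/C=C/c1ccc(NCc2cccc(Oc3ccccc3)c2)cc1` — 145 nM
compound 3 `Cc1nc(-c2ccc(C(F)(F)F)cc2)sc1CNc1ccc(OCC(=O)O)cc1` — 288 nM

In a functional assay on CHO cells for agonist activity at Free fatty acid receptor 1 (Homo sapiens) (a lower number here means that less compound is needed, a higher number that more compound is needed for the effect), compound 1 gives < 10000 nM, which is a limit of the assay and not a number (the limit of < 10000 nM in this assay, at which 1 of the 3 values shown sits). Compound 2 gives 145 nM and compound 3 gives 288 nM; the two numbers lie within the scatter of each other, so no order between compound 2 and compound 3 can be read. For the measured compounds named here, the one step between measured compounds, a step that the limit leaves unreadable from compound 1 to compound 3, cannot be sized.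

The next compound, compound 4 `O=C(CCc1ccc(NCc2cccc(Oc3ccccc3)c2)cc1)N1CCCC1`, is not yet measured. It differs from compound 2 in one place: 2-((pyrrolidin-1-yl)carbonyl)ethyl in place of 2-carboxyethenyl on an aromatic carbon. Going by the values given here, each of the three measured compounds carries a carboxylic acid at the end of the chain on this aromatic carbon; compound 4 is the first without one, and no measured step covers such an exchange. The unreadable step from compound 1 to compound 3 gives no guide either. Among the compounds with values here, the expectation rests therefore only on the fact that the sole group shared by all measured compounds is removed. For compound 4 the number in this assay is expected to rise markedly, by about a 34-fold higher number from compound 2 to compound 4 (1.54 log units; beyond the scatter). Compound 4 is estimated at 5000 nM, with a range from 800 nM to 30000 nM, and a fair chance that only a limit is reported.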

Compound 4, half-maximal effective concentration: 115 nM
Compound 4: the middle estimate sits 43-fold (1.64 log units) above what was measured; measured number below the stated range.
By their numbers in this assay, from the lowest: compounds 4, 2 and 3 (each within the scatter of the next, the first and the last beyond it).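

In this assay, replacing 2-carboxyethenyl with 2-((pyrrolidin-1-yl)carbonyl)ethyl on the aromatic carbon para to a large group gives a 1.3-fold lower number from compound 2 to compound 4 (0.10 log units; within the scatter), so the exchange opens no readable gap, although the group that enters is larger and has a ring. Compound 4 is the first compound shown without a carboxylic acid at this position, which means that the one group shared by compounds 1, 2 and 3 is not needed for a value at the level of compound 2 on this core, and the position accepts a tertiary amide end group as well as an acid. The measurements shown give no cause for this result, as nothing in them bears on why the two groups read alike.

On these data alone, the exchange changes the chain and its end group together, so it remains open how a 2-carboxyethyl group or a 2-((pyrrolidin-1-yl)carbonyl)ethenyl group would read at this position, which would separate the two changes. Also open, as far as these compounds go, is how far the tolerance extends, whether to a piperidine amide, an open-chain dimethylamide, a basic amine or a longer chain, and whether a pyrrolidine amide would hold on the core of compound 3.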